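Swapping tert-butyl for phenoxy on the aromatic ring

The compounds below may be only part of what the source reports. "The series", "measured", "known", "first", "only" and "open" are said of these compounds alone.

Compound 1 `CC1(C)CCC[C@]2(C)[C@@H](CC[C@@](C)(O)/C=C/c3cccc([N+](=O)[O-])c3)[C@](C)(O)CC[C@@H]12`: 3380 nM
Compound 2 `CC(C)(C)c1ccc(/C=C/[C@](C)(O)CC[C@@H]2[C@@]3(C)CCCC(C)(C)[C@@H]3CC[C@@]2(C)O)cc1`: 48500 nM

In a functional assay on HeLa cells (Homo sapiens) for cytotoxicity, read by MTT assay, with a stated time of 48 h (a lower number here means a stronger inhibitor, a higher number a weaker inhibitor), compound 2 gives 48500 nM, the higher of the two numbers, which makes it the weaker inhibitor of the pair. Compound 3 `CC1(C)CCC[C@]2(C)[C@@H](CC[C@@](C)(O)/C=C/c3ccc(Oc4ccccc4)cc3)[C@](C)(O)CC[C@@H]12` keeps the same core and side chain but differs from compound 2 as follows: phenoxy in place of tert-butyl on an aromatic carbon. In short, phenoxy stands in place of tert-butyl on an aromatic carbon.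

For the measured compounds named here, only one measured step bears on this change: a 14-fold higher number from compound 1 to compound 2 (1.16 log units; beyond the scatter). It is large and shows that a change of group on this aromatic ring can move the number well beyond the scatter. Going by the values given here, no measured compound carries phenoxy, so the direction is uncertain. With compound 2 at the high end of the numbers seen so far, a moderate move downward seems most likely. The expected change in this assay is a 2.4-fold lower number from compound 2 to compound 3 (0.38 log units; beyond the scatter). Compound 3 is estimated at 20000 nM, within a range of 5000 nM to 80000 nM.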

Compound 3, half-maximal inhibitory concentration: 3480 nM
Estimate against measurement, compound 3: 5.7-fold (0.76 log units) above; the measured number lies below the stated range.
By their numbers in this assay, from the lowest: compounds 1 and 3 (each within the scatter of the next); then compound 2.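

In this assay, the step of a 14-fold lower number from compound 2 to compound 3 (1.14 log units; beyond the scatter) shows that the high number of compound 2 does not hold for every large group at this aromatic carbon: the change at this one place accounts for the whole step. Phenoxy has more heavy atoms than tert-butyl, yet the number falls, and compound 3 at 3480 nM sits within the scatter of compound 1 at 3380 nM, so in these compounds the count of heavy atoms does not track the number. No measurement shown here explains why the swap has this effect.

The compounds shown leave open how an amine or a carboxylic acid would read at this aromatic carbon. They also leave open whether a plain phenyl ring, with no added group, would sit nearer compound 2 or compound 3.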